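Chain lengthening on the shared core and tolerated concentration

The source may report more compounds than this note shows. Statements on the series, on what has been measured and on what is new or still open speak of the compounds shown alone.

Among the measured compounds shown here, compound 3 `CCCCCCc1cc2cn([C@H]3C[C@H](O)[C@@H](CO)O3)c(=O)nc2s1` is the one compound of the three with a number in a functional assay on HEL cells (Homo sapiens) for cytotoxicity, read by microscopy; a lower number here means that less compound is tolerated, a higher number that more compound is tolerated: compound 3 gives 125000 nM. Compound 1 `CCCCCCCCCCc1cc2cn([C@H]3C[C@H](O)[C@@H](CO)O3)c(=O)nc2o1` reaches only a limit there, > 50000 nM. Compound 2 `CCCCc1cc2cn([C@H]3C[C@H](O)[C@@H](CO)O3)c(=O)nc2s1` likewise reaches only a limit, >= 100000 nM. Compound 4 `CCCCCCCCc1cc2cn([C@H]3C[C@H](O)[C@@H](CO)O3)c(=O)nc2s1` differs from compound 3 by ethyl in place of hydrogen on a saturated chain carbon, six bonds along the chain from an aromatic carbon. For the measured compounds named here, the one comparable step, a step that the limit leaves unreadable from compound 2 to compound 3, cannot be sized, so the measurements give no readable step to carry over to compound 4. Compound 4 is therefore expected to sit close to compound 3, with no change at the digits printed from compound 3 to compound 4 (within the scatter) as the expected step, not beyond the usual scatter. The estimate for compound 4 in this assay is 125000 nM, expected to lie between 50000 nM and 300000 nM, with a fair chance that only a limit is reported.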

Compound 4, minimum cytotoxic concentration: 20000 nM
The estimate for compound 4 lay 6.3-fold (0.80 log units) above the measured number; measured number outside the range, below it.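

In this assay, the chain position now gives a readable result: ethyl in place of hydrogen, six bonds along the chain from an aromatic carbon, produces a 6.3-fold lower number from compound 3 to compound 4 (0.80 log units; beyond the scatter), whereas the earlier step along this chain cannot be read. The longer change, butyl in place of hydrogen, produces an at least 5.0-fold lower number from compound 2 to compound 4 (0.69 log units; beyond the scatter). Compound 2 gives only a limit, so this second step has no exact size: the limit of >= 100000 nM in this assay, at which 1 of the 4 values shown sits.

From the compounds shown here alone, whether a longer chain on the core of compound 4 would lower the number further remains open. So does the effect of an amine in place of the ethyl.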